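This account rests on a few compounds, and the source may have more. Where it says the series, first, only, none or still open, it means among the compounds named here.

- Compound 1 `CCCn1c(=N)sc2cc(OC(F)(F)F)ccc21`: 4.5 mg/kg
- Compound 2 `N=c1sc2cc(OC(F)(F)F)ccc2n1CCS(=O)(=O)O`: > 10 mg/kg
- Compound 3 `CCSCCn1c(=N)sc2cc(OC(F)(F)F)ccc21`: 2.2 mg/kg

These three compounds share one core and were tested in a functional assay on the whole organism with Rattus norvegicus as the target; a higher number here means that more compound is needed for the effect, a lower number that less compound is needed. The entry for compound 2, > 10 mg/kg, is a limit of the assay and not a number. Compound 3 has the lower of the two actual numbers, 2.2 mg/kg, so less of it is needed than of compound 1, at 4.5 mg/kg.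

Compound 4 `CS(=O)(=O)CCn1c(=N)sc2cc(OC(F)(F)F)ccc21` is still unmeasured. It has methylsulfonyl in place of ethylsulfanyl on a saturated chain carbon, two bonds along the chain from an aromatic nitrogen.

All three measured steps involve this same place. Swapping methyl for ethylsulfanyl gave a 2.0-fold lower number from compound 1 to compound 3 (0.31 log units; beyond the scatter), while swapping methyl for sulfo gave an at least 2.2-fold higher number from compound 1 to compound 2 (0.34 log units; beyond the scatter). The widest contrast is an at least 4.5-fold lower number from compound 2 to compound 3 (0.65 log units; beyond the scatter). Of the measured groups, sulfo is the closest in build to methylsulfonyl, so leaving ethylsulfanyl for methylsulfonyl should move the number upward, probably not as far as sulfo did. A modest rise is therefore expected, and the estimated change is a 2.7-fold higher number from compound 3 to compound 4 (0.44 log units; beyond the scatter). For compound 4 the expected value is 6 mg/kg, with an estimated range from 2.5 mg/kg to 15 mg/kg.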

Compound 4, dose for half-maximal effect: 1.8 mg/kg
For compound 4 the middle estimate is 3.3-fold (0.52 log units) above the measured one; measured number outside the range, below it.
By their numbers in this assay, from the lowest: compounds 4 and 3 (each within the scatter of the next); then compound 1. At a limit, above all of these: compound 2.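

Swapping ethylsulfanyl for methylsulfonyl on this chain carbon, two bonds along the chain from an aromatic nitrogen, makes no difference that can be read in this assay: the result is a 1.2-fold lower number from compound 3 to compound 4 (0.09 log units; within the scatter). Among the compounds shown here, a sulfonyl group at this place is therefore no handicap in itself, as methylsulfonyl in place of the methyl of the propyl chain gives a 2.5-fold lower number from compound 1 to compound 4 (0.40 log units; beyond the scatter), and the one group that separates the two sulfonyl compounds, hydroxy or methyl on the sulfonyl sulfur, gives an at least 5.5-fold lower number from compound 2 to compound 4 (0.74 log units; beyond the scatter). The entry for compound 2 is a limit of the assay and not a number, so the true size of that last step stays unknown: the limit of > 10 mg/kg in this assay, at which 1 of the 4 values shown sits.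

Still open, from the compounds shown here alone, is how an amine, a carboxylic acid or an amide on the same chain carbon would compare with sulfo and methylsulfonyl, and whether a methylsulfinyl group or a longer chain carrying the sulfonyl would keep the number of compound 4. A whole-organism dose on its own also cannot tell why the hydroxy on the sulfur and the methyl there part so clearly.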